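Bromocatechol ether series: chain length and cytotoxicity

The source may report more compounds than this note shows. Statements on the series, on what has been measured and on what is new or still open speak of the compounds shown alone.

Compound 2 `COCc1cc(O)c(O)c(Br)c1Br` and compound 1 `CCOCc1cc(O)c(O)c(Br)c1Br` share one core and differ only in the ether chain. In a functional assay on DLD-1 cells (Homo sapiens) for cytotoxicity, read by MTT assay, with a stated time of 96 h (a lower number here means a stronger inhibitor, a higher number a weaker inhibitor), compound 2 gives 14600 nM, while compound 1 gives 13500 nM. The change between them is methyl in place of hydrogen on a saturated chain carbon bound to an oxygen on a saturated carbon and it made a step of a 1.1-fold lower number from compound 2 to compound 1 (0.03 log units; within the scatter).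

Compound 3 `CCOCc1cc(Br)c(O)c(O)c1Br` carries the same ether chain as compound 1 on a second core; the difference between the two cores is not broken down here. In this assay compound 3 gives 7150 nM, the lowest of the three numbers, though its gap to compound 1 stays within the scatter and only its gap to compound 2 lies beyond it.

Compound 4 `CCCOCc1cc(Br)c(O)c(O)c1Br` is not yet measured. It differs from compound 3 by methyl in place of hydrogen on a saturated chain carbon, two bonds along the chain from an oxygen on a saturated carbon. This is the same kind of change as in the measured pair, not the same: there the methyl enters on a carbon bound to the oxygen, here on a carbon two bonds along the chain from it. Because the earlier chain extension gave only a 1.1-fold lower number from compound 2 to compound 1 (0.03 log units; within the scatter), the step from compound 3 to compound 4 is expected to be small as well, estimated at a 1.1-fold lower number from compound 3 to compound 4 (0.04 log units; within the scatter). Compound 4 is therefore expected to give about 6500 nM in this assay, estimated to fall between 3000 nM and 14000 nM.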

Compound 4, half-maximal inhibitory concentration: 1720 nM
Beside the measured number, compound 4's estimate is 3.8-fold (0.58 log units) above it, and the stated range ends above it.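

In this assay, the ethoxy to propoxy change on the core of compound 3 gave a 4.2-fold lower number from compound 3 to compound 4 (0.62 log units; beyond the scatter), so the size of a chain extension did not carry over from the core of compound 1 to this one. The two extensions differ by more than the scatter allows: the same change on two cores in this assay, a 1.1-fold lower number (0.03 log units; within the scatter) from compound 2 to compound 1 and a 4.2-fold lower number (0.62 log units; beyond the scatter) from compound 3 to compound 4, 3.8-fold (0.58 log units) apart, beyond the scatter of two such steps

This does not show that the core alone sets the size of the step: in one pair the methyl enters on a carbon bound to the oxygen, in the other on a carbon two bonds along the chain from it, so core and place change together, and a single pair on each core gives no trend with chain length.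

The propoxy chain on the core of compound 1 would separate these two factors, and the compounds shown leave its effect open. Also open, going by these compounds, is whether a longer chain, such as butoxy, or an amine or a carboxylic acid at the chain end would keep the lower number seen for compound 4.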